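Series notes: sulfonamide substituent and the urea terminus

This account rests on a few compounds, and the source may have more. Where it says the series, first, only, none or still open, it means among the compounds named here.

Compound 1 `O=C(Nc1ccc(-c2noc(-c3cccc(NS(=O)(=O)c4cccc(Cl)c4)c3)n2)c(Cl)c1)c1cccnc1` carries a 3-chlorophenyl on the sulfonyl sulfur. In a functional assay on MDA-MB-231 cells (Homo sapiens) for antiproliferative activity, read by MTT assay, with a stated time of 72 h (on this read-out higher numbers stand for weaker inhibition and lower numbers for stronger inhibition), compound 1 gives only a limit, > 10000 nM. Compound 2 `COc1cccc(S(=O)(=O)Nc2cccc(-c3nc(-c4ccc(NC(=O)c5cccnc5)cc4Cl)no3)c2)c1` swaps in a 3-methoxyphenyl; in this assay compound 2 likewise gives only a limit, > 10000 nM. The step that the two limits leave unreadable from compound 1 to compound 2 therefore cannot be sized. For the measured compounds named here, compound 3 `CNC(=O)Nc1ccc(S(=O)(=O)Nc2cccc(-c3nc(-c4ccc(NC(=O)c5cccnc5)cc4Cl)no3)c2)cc1`, with a 4-((methylcarbamoyl)amino)phenyl on the sulfonyl sulfur, is the only member with a measured number: in this assay compound 3 gives 1300 nM. The steps of an at least 7.6-fold lower number from compound 1 to compound 3 (0.88 log units; beyond the scatter) and an at least 7.6-fold lower number from compound 2 to compound 3 (0.88 log units; beyond the scatter) both point the same way and both exceed the scatter.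

Compound 4 `O=C(Nc1ccc(-c2noc(-c3cccc(NS(=O)(=O)c4ccc(NC(=O)N5CCOCC5)cc4)c3)n2)c(Cl)c1)c1cccnc1` keeps that urea-bearing phenyl and alters only its terminus: morpholin-4-yl in place of methylamino on a carbonyl carbon. Going by the values given here, no measured step changes the group on this carbonyl carbon; the two readable steps concern the sulfonyl aryl as a whole and speak only for the urea being present. Among the compounds with values here, with no measured precedent for the change itself, compound 4 is expected to stay close to compound 3, with a 1.2-fold higher number from compound 3 to compound 4 (0.06 log units; within the scatter) expected to lie within the scatter. Compound 4 is estimated at 1500 nM, in a range of 500 nM to 4500 nM.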

Compound 4, half-maximal inhibitory concentration: > 10000 nM
Compound 4: no number, only a limit; the forecaster's own chance of this, stated with the estimate: 10%; middle value at least 6.6-fold (0.82 log units) from the limit.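

The urea terminus is not a free position: with the urea kept, morpholin-4-yl in place of methylamino on the carbonyl carbon gives an at least 7.6-fold higher number from compound 3 to compound 4 (0.88 log units; beyond the scatter). The earlier steps shown here spoke only for the urea-bearing phenyl as a whole, whereas this one shows that in this assay the presence of the urea alone does not secure a measured number, and the group on its carbonyl carbon also matters. Compound 4 gives only a limit, so the full size of the step stays unread, and the series reading is dominated by one ceiling: the limit of > 10000 nM in this assay, at which 3 of the 4 values shown sit.

The change replaces a hydrogen-bond donor, adds a six-membered ring and raises the heavy-atom count all at once, and the compounds shown do not separate these differences. On these data alone, whether an ethylamino, dimethylamino or piperidin-1-yl terminus on this carbonyl carbon would stay with compound 3 or with compound 4 remains open.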